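Extending the Methoxy Group of Compound 3 to Compound 4

The source may report more compounds than this note shows. Statements on the series, on what has been measured and on what is new or still open speak of the compounds shown alone.

Compounds measured so far, with their inhibition at a single concentration:
compound 1, `COc1cc(O)c(C(=O)OCC2CCCCC2)c(/C=C/CN2C(=O)C=CC2=O)c1`: 0%
compound 2, `COc1cc(O)c(C(=O)OC(C)C)c(/C=C/CN2C(=O)C=CC2=O)c1`: 4.1%
compound 3, `CCN(CC)C/C=C/C(=O)NC/C=C/c1cc(OC)cc(O)c1C(=O)OC(C)C`: 5.2%

In an assay on isolated protein for inhibition of MAP kinase-interacting serine/threonine-protein kinase 2 (Homo sapiens), tested at 10 uM (on this read-out lower numbers stand for less inhibition and higher numbers for more inhibition at the one concentration tested (going by the name of the read-out)), compound 1 gives 0%, compound 2 gives 4.1% and compound 3 gives 5.2%. Compound 3 carries the top number of the three, but its gaps to compound 2 and to compound 1 both lie within the usual scatter, so the three compounds cannot be separated on these numbers; all of them show little inhibition at the tested concentration.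

Compound 4, `CCN(CC)C/C=C/C(=O)NC/C=C/c1cc(OCCc2ccc(F)cc2)cc(O)c1C(=O)OC(C)C`, differs from compound 3 in one place: 4-fluorobenzyl in place of hydrogen on a saturated chain carbon bound to an oxygen on an aromatic ring.

Within the data shown here, only one measured step is available, a number 4.1 percentage points higher from compound 1 to compound 2 (within the scatter), and that step changes a different part of the shared core, not the methoxy group. It says little about the present change, other than that a change of similar scale elsewhere moved the read-out only within the scatter. Among the measured compounds shown here, no measured step touches the methoxy group itself, so the expectation rests on the low level of all three measured compounds.

The step from compound 3 to compound 4 is expected to be a number 0.8 percentage points higher from compound 3 to compound 4 (within the scatter), no larger than the scatter. Compound 4 is estimated at 6%, within a range from 0% to 22%.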

Compound 4, a percentage reported as inhibition, at one concentration (the size of the read-out at that concentration, not a potency): 0.8%
Beside the measured number, compound 4's estimate is 5.2 percentage points above it; the range from low to high includes it.
By their numbers in this assay, from the lowest: compounds 1, 4, 2 and 3 (each within the scatter of the next).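

Among these compounds, this is the first measured change at the methoxy group, and it is a large one: methyl becomes 2-(4-fluorophenyl)ethyl, adding 8 heavy atoms and one six-membered aromatic ring. In this assay, among the compounds shown here, the result is a number 4.4 percentage points lower from compound 3 to compound 4 (within the scatter), so even this change on a saturated chain carbon bound to an oxygen on an aromatic ring gives no gain in inhibition that can be told from the scatter, and compound 4 joins the earlier compounds in showing little inhibition at the tested concentration. Nothing measured here offers an explanation for this result.

Compound 3 already starts so close to no inhibition that a harmful effect of the change could hardly show up on this read-out, so the step says little about whether the inhibition would stay level with such a group at this position in a compound with a higher number. As far as these compounds go, it also remains open whether an amine or a carboxylic acid at the end of the chain, or a longer chain without the fluorophenyl ring, would raise inhibition at this position, and whether the same change would behave alike on compound 2.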